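Working notes: one phenyl substituent change, compound 2 to compound 3

A few compounds are considered here, and "the series" means these few. Any claim that something is new, unique, unknown or untested is made for them only; others in the source may bear on it.

Measured so far:
compound 1, `CN1CCN(CCCOc2cccc3nc(Nc4ccc(Cl)c(C(F)(F)F)c4)ccc23)CC1`: 8130 nM
compound 2, `CN1CCN(CCCOc2cccc3nc(Nc4ccc(Cl)c(F)c4)ccc23)CC1`: 9120 nM

In a functional assay on cells (Panel NCI-60 (60 carcinoma cell lines), Homo sapiens) for inhibition, read by sulforhodamine B assay, with a stated time of 48 h (on this read-out lower numbers stand for higher toxicity in this test and higher numbers for lower toxicity in this test), compound 1 gives 8130 nM and compound 2 gives 9120 nM. Among the compounds with values here, of the two numbers, the figure of compound 2 is the upper one, but the only measured step, a 1.1-fold higher number from compound 1 to compound 2 (0.05 log units; within the scatter), is within the scatter, so the two compounds cannot be ranked on this read-out.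

Compound 3, `CN1CCN(CCCOc2cccc3nc(Nc4cccc(Cl)c4)ccc23)CC1`, is not yet measured. Its change from compound 2 is 3-chlorophenyl in place of 4-chloro-3-fluorophenyl on a nitrogen on an aromatic ring. Within the data shown here, no measured step covers this exact change. Among the measured compounds shown here, the one step to hand, a 1.1-fold higher number from compound 1 to compound 2 (0.05 log units; within the scatter), swapped a single group on the same ring and left the number within the scatter; the change to compound 3 goes further, removing one substituent and shifting the other, so the range is kept wide. No shift beyond the scatter is expected for compound 3 on this basis. Compound 3 is estimated at 9000 nM, range 4000 nM to 20000 nM, which means an expected step of a 1.0-fold lower number from compound 2 to compound 3 (0.01 log units; within the scatter).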

Compound 3, concentration lethal to 50% of the cells: 10700 nM
Compound 3: middle estimate off by 1.2-fold (0.08 log units), on the low side, and the stated range covers the measured number.
By their numbers in this assay, from the lowest: compounds 1, 2 and 3 (each within the scatter of the next).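

In this assay the group on the aromatic nitrogen goes from 4-chloro-3-fluorophenyl to 3-chlorophenyl with a 1.2-fold higher number from compound 2 to compound 3 (0.07 log units; within the scatter), so a change that removes one substituent and shifts the other reads no differently from the earlier swap of a single group. The other new pair, 4-chloro-3-(trifluoromethyl)phenyl to 3-chlorophenyl, gives a 1.3-fold higher number from compound 1 to compound 3 (0.12 log units; within the scatter), which leaves all three compounds unranked and shows that these three halogen patterns on the phenyl ring cannot be told apart on this read-out. Nothing at hand bears on why the numbers sit so close together.

On these data alone, all three compounds keep a chlorine on the phenyl ring, so it remains open whether an unsubstituted phenyl, or a methoxy or an amine on that ring, would give a step beyond the scatter. The shared core and its side chain are also constant here, which leaves open what a longer chain or a morpholine at the end of that chain would do to this number.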